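Swapping Ethyl for Butoxy on a Sulfonamide Core

The source may report more compounds than this note shows. Statements on the series, on what has been measured and on what is new or still open speak of the compounds shown alone.

Compound 1 `CCc1ccc(S(=O)(=O)N2CCC(N3CCC(C)CC3)CC2)cc1`: > 5000 nM
Compound 2 `CC1CCN(C2CCN(S(=O)(=O)c3cnc(Cl)s3)CC2)CC1`: 1800 nM
Compound 3 `CC1CCN(C2CCN(S(=O)(=O)c3nccn3C)CC2)CC1`: > 5000 nM

Of the compounds shown here, three sharing one core have been tested in a functional assay on DLD-1 cells (Homo sapiens) for antiproliferative activity, read by CellTiter-Glo, with a stated time of 72 h; on this read-out higher numbers stand for weaker inhibition and lower numbers for stronger inhibition. Compound 1 gives > 5000 nM, which is a limit of the assay rather than a measured number. Compound 3 likewise gives > 5000 nM, again only a limit. Compound 2 gives 1800 nM and is the only one of the three with a definite value.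

The measured steps all concern the group on the sulfonyl sulfur: an at least 2.7-fold lower number from compound 1 to compound 2 (0.44 log units; beyond the scatter), an at least 2.7-fold higher number from compound 2 to compound 3 (0.44 log units; beyond the scatter), and a step that the two limits leave unreadable from compound 1 to compound 3. Two of the three results sit at the limit of > 5000 nM in this assay, at which 2 of the 3 values shown sit, so little can be read about how far compound 1 actually lies from that edge.

Compound 4 `CCCCOc1ccc(S(=O)(=O)N2CCC(N3CCC(C)CC3)CC2)cc1` differs from compound 1 in one place: butoxy in place of ethyl on an aromatic carbon. Among the measured compounds shown here, none of the measured steps touches this part of the molecule, so they offer no direct guide; the only anchor is that compound 1 itself is at the limit. The expected step is therefore none beyond the scatter, with compound 4 most likely also ending at a limit. In this assay compound 4 is expected to give 6000 nM, with a range from 2000 nM to 20000 nM. This estimate corresponds to an expected step that the limit leaves unreadable from compound 1 to compound 4.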

Compound 4, half-maximal inhibitory concentration: 2300 nM
Compound 4: middle estimate off by 2.6-fold (0.42 log units), on the high side; the measured number falls inside the stated range.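

In this assay, the place on the six-membered aromatic ring para to a large group proves able to shift the result: butoxy in place of ethyl gives an at least 2.1-fold lower number from compound 1 to compound 4 (0.33 log units; beyond the scatter). The earlier comparisons shown here exchanged the entire group on the sulfonyl sulfur, whereas this one keeps the aromatic ring of compound 1 and changes only the group it carries, showing that such a smaller edit can also move the read-out beyond the scatter. The step is only a minimum and its true size cannot be read, because compound 1 sits at a limit and not at a measured number: the limit of > 5000 nM in this assay, at which 2 of the 4 values shown sit.

What remains open is which part of the butoxy group matters, as it differs from ethyl both in its oxygen and in its longer chain, and the shown compounds do not separate the two. A plain butyl chain at this place would address that question, while a methoxy or a longer alkoxy chain would show whether the trend follows chain length at all.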